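Swapping Trifluoromethyl for Methoxy: Expected Half-Life

This account rests on a few compounds, and the source may have more. Where it says the series, first, only, none or still open, it means among the compounds named here.

Among the measured compounds shown here, compound 2 `C[C@H](NC(CC(=O)c1ccccc1C(F)(F)F)C(=O)O)c1ccccc1` gives 0.2 h in a physicochemical assay for pharmacokinetics, at pH 7.4 (on this read-out lower numbers stand for a shorter-lived compound and higher numbers for a longer-lived compound), the lower of the two numbers so far; compound 1 `C[C@H](NC(CC(=O)c1ccccc1Cl)C(=O)O)c1ccccc1` gives 0.4 h, and the step of a 2.0-fold lower number from compound 1 to compound 2 (0.30 log units; within the scatter) lies within the scatter. Compound 3 `COc1ccccc1C(=O)CC(N[C@@H](C)c1ccccc1)C(=O)O` differs from compound 2 in one place: methoxy in place of trifluoromethyl on an aromatic carbon. For the measured compounds named here, the only measured step that bears on this change is a 2.0-fold lower number from compound 1 to compound 2 (0.30 log units; within the scatter), which stayed within the scatter, so no step beyond the scatter is expected here either. For compound 3 the estimate is 0.3 h, between 0.1 h and 0.8 h, meaning an expected step of a 1.5-fold higher number from compound 2 to compound 3 (0.18 log units; within the scatter).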

Compound 3, half-life: 11.6 h
Estimate against measurement, compound 3: 39-fold (1.59 log units) below, and the stated range ends below it.
By their numbers in this assay, from the lowest: compounds 2 and 1 (each within the scatter of the next); then compound 3.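

In this assay, the swap between chloro and trifluoromethyl stayed within the scatter, which gave no sign that this aromatic carbon, ortho to a large group, mattered much. Methoxy shows that it can: it gives a 58-fold higher number from compound 2 to compound 3 (1.76 log units; beyond the scatter) and a 29-fold higher number from compound 1 to compound 3 (1.46 log units; beyond the scatter), so the group here can shift the half-life strongly. No measurement shown gives a reason for this jump. As far as these compounds go, whether a hydroxyl, an ethoxy or an amine on this carbon would give a similar half-life stays open. So does whether methoxy would have the same effect on another carbon of the ring.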